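This account rests on a few compounds, and the source may have more. Where it says the series, first, only, none or still open, it means among the compounds named here.

Measured compounds in an assay for inhibition of Apoptosis regulator Bcl-2 (Homo sapiens), read by fluorescence polarization, with a stated time of 2 h; a lower number here means a stronger inhibitor, a higher number a weaker inhibitor:
compound 1 `CCOc1cccc(S(=O)(=O)Nc2ccc(N3CCN(c4cccc(-c5c(C(=O)NCCCN6CCN(C)CC6)c(C)n(C)c5-c5ccc(Cl)cc5)c4)CC3)cc2)c1` gives 1620 nM
compound 2 `Cc1c(C(=O)NCCCN2CCN(C)CC2)c(-c2cccc(N3CCN(c4ccc(NS(=O)(=O)c5cccc(S(=O)(=O)C(F)(F)F)c5)cc4)CC3)c2)c(-c2ccc(Cl)cc2)n1C` gives 153 nM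
compound 3 `Cc1cccc(S(=O)(=O)Nc2ccc(N3CCN(c4cccc(-c5c(C(=O)NCCCN6CCN(C)CC6)c(C)n(C)c5-c5ccc(Cl)cc5)c4)CC3)cc2)c1` gives 689 nM

Compound 3 holds the second highest of the three numbers; nearest to it is compound 1, with a 2.4-fold lower number from compound 1 to compound 3 (0.37 log units; beyond the scatter), furthest compound 2, with a 4.5-fold higher number from compound 2 to compound 3 (0.65 log units; beyond the scatter).

Compound 4 `COc1cccc(S(=O)(=O)Nc2ccc(N3CCN(c4cccc(-c5c(C(=O)NCCCN6CCN(C)CC6)c(C)n(C)c5-c5ccc(Cl)cc5)c4)CC3)cc2)c1` differs from compound 3 in one place: methoxy in place of methyl on an aromatic carbon. Among the compounds with values here, no measured step swaps methyl for methoxy. The closest is the ethoxy-to-methyl step a 2.4-fold lower number from compound 1 to compound 3 (0.37 log units; beyond the scatter), modest in size; the large step of an 11-fold lower number from compound 1 to compound 2 (1.02 log units; beyond the scatter) involves (trifluoromethyl)sulfonyl and bears little here. Methoxy lying between methyl and ethoxy, a modest rise from compound 3 is expected: a 1.5-fold higher number from compound 3 to compound 4 (0.16 log units; within the scatter). Compound 4 is estimated at 1000 nM, range 450 nM to 2300 nM.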

Compound 4, half-maximal inhibitory concentration: 802 nM
Beside the measured number, compound 4's estimate is 1.2-fold (0.10 log units) above it; low and high end bracket the measured number.
By their numbers in this assay, from the lowest: compound 2; then compounds 3 and 4 (each within the scatter of the next); then compound 1.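

In this assay, methoxy and methyl on this aromatic carbon cannot be told apart, with a 1.2-fold higher number from compound 3 to compound 4 (0.07 log units; within the scatter). Going from ethoxy to methoxy does move the number, with a 2.0-fold lower number from compound 1 to compound 4 (0.31 log units; beyond the scatter), and (trifluoromethyl)sulfonyl stays clearly ahead of methoxy, with a 5.2-fold higher number from compound 2 to compound 4 (0.72 log units; beyond the scatter), so among the alkyl and alkoxy groups shown only ethoxy stands apart. Nothing at hand explains these steps.

On these data alone, whether an amine or a fluorine here would fall with methyl and methoxy or nearer (trifluoromethyl)sulfonyl stays open. So does whether a propoxy or longer chain would raise the number beyond ethoxy.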